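A few compounds are considered here, and "the series" means these few. Any claim that something is new, unique, unknown or untested is made for them only; others in the source may bear on it.

Measured so far:
Compound 1, `S=c1oc(-c2ccc3c(c2)OCCO3)nn1CN1CCN(c2ccc(Cl)cc2)CC1`: in a functional assay on HeLa cells (Homo sapiens) for antiproliferative activity, read by MTT assay, with a stated time of 48 h (a higher number here means a weaker inhibitor, a lower number a stronger inhibitor), compound 1 gives > 50000 nM, which is a limit of the assay and not a number.
Compound 2, `S=c1oc(-c2ccc3c(c2)OCCO3)nn1CN1CCN(c2cccc(Cl)c2)CC1`: in this assay compound 2 gives 47200 nM.
Compound 3, `COc1ccccc1N1CCN(Cn2nc(-c3ccc4c(c3)OCCO4)oc2=S)CC1`: in this assay compound 3 gives > 50000 nM, which is a limit of the assay and not a number.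

Compound 3 therefore stands at the limit of this assay, and only a limit is known for it; the same holds for compound 1, as the line the limit of > 50000 nM in this assay, at which 2 of the 3 values shown sit, records. Compound 4, `Fc1ccc(N2CCN(Cn3nc(-c4ccc5c(c4)OCCO5)oc3=S)CC2)cc1`, differs from compound 3 by 4-fluorophenyl in place of 2-methoxyphenyl on an amine nitrogen in a ring. The measured steps that bear on this change all swap the aryl group on the same ring nitrogen: an at least 1.0-fold lower number from compound 1 to compound 2 (0.02 log units; that floor lies within the scatter), a step within the scatter; an at least 1.0-fold higher number from compound 2 to compound 3 (0.02 log units; that floor lies within the scatter), again only a floor within the scatter; and a step that the two limits leave unreadable from compound 1 to compound 3, which the two limits leave unreadable. None of these changes on the aryl group moved the value away from the limit region of this assay, with compound 2 sitting only just inside the measurable range. Compound 4 is therefore expected to behave like compound 3, with the step of a number no higher from compound 3 to compound 4 (the limit leaves the size open) expected to stay within the scatter. The estimate for compound 4 in this assay is 50000 nM, in a range from 25000 nM to 100000 nM, and it is expected that the assay will most likely report only a limit again.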

Compound 4, half-maximal inhibitory concentration: > 50000 nM
Compound 4 was reported as a limit; the forecaster's own chance of this, stated with the estimate: 70%; the middle value lies on the limit itself.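

With 4-fluorophenyl on the amine nitrogen in a ring, a fluorine-bearing aryl group now joins the chlorine- and methoxy-bearing ones in the limit region of this assay, and compound 2 is the only compound shown that goes against this pattern, sitting just inside the measurable range: the limit of > 50000 nM in this assay, at which 3 of the 4 values shown sit.

Among the compounds shown here, the only readable step is an at least 1.0-fold higher number from compound 2 to compound 4 (0.02 log units; that floor lies within the scatter), so the 4-fluorophenyl group of compound 4 cannot be set apart from the 3-chlorophenyl group of compound 2 in this assay. The steps from compound 3 to compound 4 and from compound 1 to compound 4 join limit to limit and cannot be read.

The compounds shown leave open whether any group at this position can bring a value clearly inside the measurable range of this assay, or whether all of these aryl groups lie equally far from it. An amine or a carboxylic acid on the phenyl ring, or a longer chain joining the ring nitrogen to the shared core, would test whether this part of the structure can move the value at all.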